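Replacing the amide tail of compound 1 with a dimethylaminoethyl amide

A few compounds are considered here, and "the series" means these few. Any claim that something is new, unique, unknown or untested is made for them only; others in the source may bear on it.

Compound 1 `CCCC(=O)OCSc1ccccc1C(=O)NCCCC(N)=O` was tested in an ADME assay on CEM-SS cells (Homo sapiens) for cytotoxicity, read by XTT assay, with a stated time of 6 days (a higher number here means that more compound is tolerated, a lower number that less compound is tolerated), and compound 1 gives 56.6 uM. Compound 2 `CCCC(=O)OCSc1ccccc1C(=O)N[C@@H]1CCC[C@@H]1C(N)=O` gives 90 uM and compound 3 `CCCC(=O)OCSc1ccccc1C(=O)N(C)CC(=O)NC` gives 62.5 uM, so all three numbers sit within the usual scatter of one another: a 1.6-fold higher number from compound 1 to compound 2 (0.20 log units; within the scatter) and a 1.1-fold higher number from compound 1 to compound 3 (0.04 log units; within the scatter). Compound 4 `CCCC(=O)OCSc1ccccc1C(=O)NCC(=O)NCCN(C)C` differs from compound 1 in one place: (2-(dimethylamino)ethyl)carbamoyl in place of 2-carbamoylethyl on a saturated chain carbon bound to an amide-type nitrogen. Both measured steps alter the same amide-type tail and neither moved the number beyond the scatter, so no change beyond the scatter is expected here either, which is a 1.1-fold higher number from compound 1 to compound 4 (0.03 log units; within the scatter). Compound 4 is therefore estimated at 60 uM, with a range from 30 uM to 120 uM.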

Compound 4, half-maximal toxic concentration: 76.9 uM
Estimate against measurement, compound 4: 1.3-fold (0.11 log units) below; the range from low to high includes it.
By their numbers in this assay, from the lowest: compounds 1, 3, 4 and 2 (each within the scatter of the next).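

In this assay, the step to the larger (2-(dimethylamino)ethyl)carbamoyl, which brings a second nitrogen into the tail, is a 1.4-fold higher number from compound 1 to compound 4 (0.13 log units; within the scatter) and so gives no change that can be told from the scatter. This place on a saturated chain carbon bound to an amide-type nitrogen therefore accepts a tail ending in dimethylamino, at least in this one pair of compounds. Nothing available here bears on why the number holds. Still open, going by these compounds, is whether a carboxylic acid or a longer chain at the end of this tail would move the number beyond the scatter.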